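A few compounds are considered here, and "the series" means these few. Any claim that something is new, unique, unknown or untested is made for them only; others in the source may bear on it.

Of the compounds shown here, three sharing one core have been measured in a functional assay on HT-29 cells (Homo sapiens) for inhibition, read by MTT assay, with a stated time of 48 h; a lower number here means a stronger inhibitor, a higher number a weaker inhibitor. There, compound 1 `COc1cc(/C=C/c2ccc(NC(=O)/C=C/c3cc(OC)c(O)c(OC)c3)cc2)cc(OC)c1` gives 3080 nM, compound 2 `COc1cc(/C=C/c2ccc(NC(=O)/C=C/c3ccc(C(F)(F)F)cc3)cc2)cc(OC)c1` gives 1780 nM and compound 3 `COc1cc(/C=C/c2ccc(NC(=O)/C=C/c3ccc([N+](=O)[O-])cc3)cc2)cc(OC)c1` gives 10700 nM. Compound 3 stands highest of the three and is the weakest inhibitor so far, as shown by a 3.5-fold higher number from compound 1 to compound 3 (0.54 log units; beyond the scatter) and a 6.0-fold higher number from compound 2 to compound 3 (0.78 log units; beyond the scatter).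

Compound 4 `COc1cc(/C=C/c2ccc(NC(=O)/C=C/c3ccc(F)cc3F)cc2)cc(OC)c1` has not yet been measured. It differs from compound 3 by one exchange: 2,4-difluorophenyl in place of 4-nitrophenyl on a double-bonded chain carbon bound to a double-bonded chain carbon, with 2,4-difluorophenyl in place of 4-nitrophenyl on a double-bonded chain carbon bound to a double-bonded chain carbon.

The steps that bear on this are the two that reach compound 3 through a change of the same group, given above. The third, a 1.7-fold lower number from compound 1 to compound 2 (0.24 log units; within the scatter), shows that the other two groups do not separate. Compound 4 also lacks 4-nitrophenyl, so a modest drop toward compound 1 and compound 2 is expected in this assay, though neither measured group is the one entering here. The estimated step is a 3.6-fold lower number from compound 3 to compound 4 (0.55 log units; beyond the scatter). Compound 4 is expected at 3000 nM, with an estimated range of 1000 nM to 9000 nM.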

Compound 4, half-maximal inhibitory concentration: 18100 nM
Beside the measured number, compound 4's estimate is 6.0-fold (0.78 log units) below it; the whole stated range lies below it.
By their numbers in this assay, from the lowest: compounds 2 and 1 (each within the scatter of the next); then compounds 3 and 4 (each within the scatter of the next).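

In this assay, the 2,4-difluorophenyl group does not separate from 4-nitrophenyl at this place (a 1.7-fold higher number from compound 3 to compound 4 (0.23 log units; within the scatter)), so the absence of 4-nitrophenyl alone does not bring a compound toward compound 1 or compound 2. Fluorine on the ring does not suffice either, since compound 4 stands apart from the trifluoromethyl-bearing compound 2 (a 10-fold higher number from compound 2 to compound 4 (1.01 log units; beyond the scatter)) and from the 4-hydroxy-3,5-dimethoxyphenyl-bearing compound 1 (a 5.9-fold higher number from compound 1 to compound 4 (0.77 log units; beyond the scatter)), leaving the four compounds in two pairs, compounds 1 and 2 against compounds 3 and 4. No measurement offered here explains this division.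

On these data alone, what sets the two pairs apart remains open. It is also unknown which pair a phenyl ring carrying an amine or a carboxylic acid at this place would join.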